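A few compounds are considered here, and "the series" means these few. Any claim that something is new, unique, unknown or untested is made for them only; others in the source may bear on it.

Measured so far:
compound 1, `CCc1cccc(NC(=O)N[C@@H](C)c2ccccc2)c1`: 86%
compound 2, `C[C@H](NC(=O)Nc1cccc(F)c1)c1ccccc1`: 88%

Both compounds were tested in an ADME assay on the whole organism with Oryza sativa as the target, tested at 10 uM; on this read-out higher numbers stand for a weaker effect at the one concentration tested and lower numbers for a stronger effect. On this read-out compound 2 and compound 1 cannot be told apart: the step of a number 2 percentage points higher from compound 1 to compound 2 (within the scatter) lies within the scatter, so the two numbers count as the same result, and neither compound can be called stronger or weaker than the other.

Compound 3, `C[C@H](NC(=O)Nc1cccc(Br)c1)c1ccccc1`, has not been measured. It differs from compound 2 in one place: bromo in place of fluoro on an aromatic carbon. No measured step involves bromo, so nothing shown here speaks directly to this change. Among the measured compounds shown here, the only step that bears on it at all is the one at the same position, where a fluoro replaced an ethyl; that step, a number 2 percentage points higher from compound 1 to compound 2 (within the scatter), stayed within the scatter. On that basis, the expected step of a number 1 percentage points lower from compound 2 to compound 3 (within the scatter) is no change beyond the scatter. The estimate for compound 3 in this assay is 87%, with a range from 72% to 100%.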

Compound 3, a percentage reported as activity, at one concentration (the size of the read-out at that concentration, not a potency): 99%
For compound 3 the middle estimate is 12 percentage points below the measured one; measured number inside the range.
By their numbers in this assay, from the lowest: compounds 1 and 2 (each within the scatter of the next); then compound 3.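

In this assay, the group on this aromatic carbon turns out to matter: bromo in place of fluoro gives a number 11 percentage points higher from compound 2 to compound 3 (beyond the scatter), and bromo in place of ethyl gives a number 13 percentage points higher from compound 1 to compound 3 (beyond the scatter). Until now the position looked indifferent, since the only earlier change there gave a number 2 percentage points higher from compound 1 to compound 2 (within the scatter), but among these three groups bromo alone stands apart, and compound 3 shows the weakest effect at the one concentration tested. Nothing available here explains why bromo behaves differently from fluoro and ethyl.

On these data alone, what remains open is whether this shift belongs to bromo alone or would also appear with other groups on the same carbon, such as chloro, methoxy, an amine, a carboxylic acid or a longer chain like propyl. Three compounds also cannot show whether the same replacement would have a similar effect on a different core, and a reading at a single concentration gives the size of the effect there, not a potency.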